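The source may hold more compounds than are shown below. What is called first, only, known or untested is meant among the compounds shown, and "the series" means these compounds.

For the measured compounds named here, the two compounds measured so far share one core and differ in a single substituent. Compound 1 `N[C@H]1CC[C@H](Nc2ccc3ncc(-c4cnc(Nc5ncccc5F)nc4)n3n2)CC1` gives 0.2 in a physicochemical assay for lipophilicity (a higher number here means a more lipophilic compound, a lower number a more polar compound), while compound 2 `CN1CCN(c2ccc3ncc(-c4cnc(Nc5ncccc5F)nc4)n3n2)CC1` gives 2.2 in this assay, the higher of the two numbers. Going by the values given here, the one step that has been measured, a number 2.00 log units higher from compound 1 to compound 2 (beyond the scatter), shows that exchanging the substituent on this aromatic carbon can move the number a long way.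

Compound 3 `Fc1cccnc1Nc1ncc(-c2cnc3ccc(N[C@H]4CCNC4)nn23)cn1` is not yet measured; the change from compound 2 is (pyrrolidin-3-yl)amino in place of 4-methylpiperazin-1-yl on an aromatic carbon. This is the reverse kind of exchange to the measured step: the group that enters is, like the group of compound 1, a ring-bound amine with two hydrogen-bond donors rather than a methylpiperazine with none. A drop of roughly the same size is therefore expected. For compound 3 the estimate is 0.5, with a likely range from -0.3 to 1.3, which means an expected step of a number 1.70 log units lower from compound 2 to compound 3 (beyond the scatter).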

Compound 3, distribution coefficient: 0.4
Compound 3: middle estimate off by 0.10 log units, on the high side; measured number inside the range.
By their numbers in this assay, from the lowest: compounds 1 and 3 (each within the scatter of the next); then compound 2.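

In this assay the step to a second amino-linked group, a number 1.80 log units lower from compound 2 to compound 3 (beyond the scatter), shows that the large shift seen at this aromatic carbon is not unique to the (4-aminocyclohexyl)amino group of compound 1. Exchanging the group on the linking nitrogen, pyrrolidin-3-yl in place of 4-aminocyclohexyl, gives a number 0.20 log units higher from compound 1 to compound 3 (within the scatter), so these two different rings cannot be told apart in this measurement. No measured evidence accompanies these numbers to explain the shift.

The exchange from 4-methylpiperazin-1-yl alters the ring, the linking nitrogen and the donor count together, so the compounds shown do not reveal which of these changes matters. A piperazin-1-yl group or a (1-methylpyrrolidin-3-yl)amino group on this carbon would help separate them.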